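This account rests on a few compounds, and the source may have more. Where it says the series, first, only, none or still open, it means among the compounds named here.

In a functional assay on MCF7 cells (Homo sapiens) for inhibition, read by MTT assay, with a stated time of 48 h (on this read-out higher numbers stand for weaker inhibition of growth and lower numbers for stronger inhibition of growth), compound 1 (`COc1ccc(C(=O)N2N=C(c3ccccc3)CC2c2cn(C)c3ccccc23)cn1`) gives 4310 nM. Compound 2 (`Cn1cc(C2CC(c3ccccc3)=NN2C(=O)c2cccnc2Cl)c2ccccc21`) is reported only as a limit of the assay, > 10000 nM. The one measured step among these compounds is an at least 2.3-fold higher number from compound 1 to compound 2 (0.36 log units; beyond the scatter), and it is a bound on the size of the step, not a full measure of it. For the measured compounds named here, compound 3 (`Cn1cc(C2CC(c3ccccc3)=NN2C(=O)c2cccnc2)c2cc(Br)ccc21`) gives 1520 nM, the lowest number so far and lower than the number for compound 1.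

Compound 4 (`COc1cc(C2=NN(C(=O)c3cccnc3)C(c3cn(C)c4ccc(Br)cc34)C2)cc(OC)c1OC`) departs from compound 3 at a single place, with 3,4,5-trimethoxyphenyl in place of phenyl on a carbon with a double bond to nitrogen. Going by the values given here, no measured step touches this place. Among the compounds with values here, the step of an at least 2.3-fold higher number from compound 1 to compound 2 (0.36 log units; beyond the scatter) concerns the group on the carbonyl carbon, so it shows only that one exchange on this scaffold can move the number beyond the scatter, and it gives no direction for the present change. In this assay no firm shift is therefore expected, only a slight lean towards a lower number, and that lean is a judgement and not something the data show. The expected change is a 1.7-fold lower number from compound 3 to compound 4 (0.23 log units; within the scatter). For compound 4 the estimated value is 900 nM, with an expected range from 200 nM to 4000 nM.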

Compound 4, concentration for 50% growth inhibition: > 10000 nM
Compound 4: no number, only a limit; the forecaster's own chance of this, stated with the estimate: 5%; at least 11-fold (1.04 log units) between middle value and limit.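

In this assay, for the compounds shown here, the step of an at least 6.5-fold higher number from compound 3 to compound 4 (0.81 log units; beyond the scatter) is the first measured change at the group on the carbon with a double bond to nitrogen, and it runs towards weaker inhibition of growth, so this place is not indifferent to what it carries. Compound 4 is reported only as a limit of the assay, > 10000 nM, which makes the step a bound on the size of the change and leaves its full size unknown: the limit of > 10000 nM in this assay, at which 2 of the 4 values shown sit. The earlier step, an at least 2.3-fold higher number from compound 1 to compound 2 (0.36 log units; beyond the scatter), concerned the group on the carbonyl carbon, so the new step adds a second place on this scaffold where a single exchange moves the number beyond the scatter, again upwards.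

As far as these compounds go, only phenyl and 3,4,5-trimethoxyphenyl stand at this place, so it remains open whether a single methoxy group on the phenyl, a 4-chlorophenyl or a plain methyl would keep the number near that of compound 3. Also open, from the compounds shown here alone, is whether the same exchange would act alike with a 6-methoxypyridin-3-yl on the carbonyl carbon, or on a core without the bromine.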